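A few compounds are considered here, and "the series" means these few. Any claim that something is new, unique, unknown or untested is made for them only; others in the source may bear on it.

Measured compounds:
compound 1, `Cc1cc(S(=O)(=O)/N=C(\N)N/N=C/C#Cc2ccccc2)c(SCc2ccccc2C)cc1Cl`, 19000 nM;
compound 2, `C/C(C#Cc1ccccc1)=N\N/C(N)=N/S(=O)(=O)c1cc(C)c(Cl)cc1SCc1ccccc1C`, 142000 nM;
compound 3, `Cc1cc(S(=O)(=O)/N=C(\N)N/N=C/C#Cc2ccccc2)c(SCc2ccccc2Cl)cc1Cl`, 27000 nM.

In a functional assay on HCT-116 cells (Homo sapiens) for antiproliferative activity, read by MTT assay, with a stated time of 72 h (on this read-out higher numbers stand for weaker inhibition and lower numbers for stronger inhibition), compound 1 gives 19000 nM and compound 2 gives 142000 nM. The change between them is a group of 11 heavy atoms (10 carbon, 1 nitrogen; one six-membered aromatic ring of carbon only) in place of a group of 10 heavy atoms (9 carbon, 1 nitrogen; one six-membered aromatic ring of carbon only), on an amine nitrogen, and it made a step of a 7.5-fold higher number from compound 1 to compound 2 (0.87 log units; beyond the scatter).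

Compound 3 differs from compound 1 in its core by chloro in place of methyl on an aromatic carbon; in this assay compound 3 gives 27000 nM, a step of a 1.4-fold higher number from compound 1 to compound 3 (0.15 log units; within the scatter), so the two cores are not separated here.

Compound 4, `C/C(C#Cc1ccccc1)=N\N/C(N)=N/S(=O)(=O)c1cc(C)c(Cl)cc1SCc1ccccc1Cl`, has not been measured in this assay. It differs from compound 3 by a group of 11 heavy atoms (10 carbon, 1 nitrogen; one six-membered aromatic ring of carbon only) in place of a group of 10 heavy atoms (9 carbon, 1 nitrogen; one six-membered aromatic ring of carbon only), on an amine nitrogen, which is the same change that turned compound 1 into compound 2, made at the same kind of place. Since the two cores gave numbers within the scatter of each other, the earlier step of a 7.5-fold higher number from compound 1 to compound 2 (0.87 log units; beyond the scatter) is expected to repeat on the second core. On that basis the estimated step is a 6.7-fold higher number from compound 3 to compound 4 (0.82 log units; beyond the scatter). Compound 4 is therefore expected to give about 180000 nM in this assay, estimated between 60000 nM and 500000 nM.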

Compound 4, half-maximal inhibitory concentration: 129000 nM
For compound 4 the middle estimate is 1.4-fold (0.14 log units) above the measured one; measured number inside the range.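

In this assay, the exchange on the amine nitrogen carried over to the second core, giving a 4.8-fold higher number from compound 3 to compound 4 (0.68 log units; beyond the scatter), and the two steps agree: the same change on two cores in this assay, a 7.5-fold higher number (0.87 log units; beyond the scatter) from compound 1 to compound 2 and a 4.8-fold higher number (0.68 log units; beyond the scatter) from compound 3 to compound 4, 1.6-fold (0.19 log units) apart, within the scatter of two such steps

The exchange of chloro for methyl on an aromatic carbon stayed within the scatter in the second pair as well, giving a 1.1-fold lower number from compound 2 to compound 4 (0.04 log units; within the scatter), and it did not alter the outcome of the first exchange: the same change on two cores in this assay, a 1.4-fold higher number (0.15 log units; within the scatter) from compound 1 to compound 3 and a 1.1-fold lower number (0.04 log units; within the scatter) from compound 2 to compound 4, 1.6-fold (0.19 log units) apart, within the scatter of two such steps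

This shows that the step transfers between these two cores in this one assay, but the cores differ only by that chloro or methyl, so it does not show that the step would hold on a core that differs more, nor does it explain the size of the step.

Going by these compounds, it remains open whether an entering group with a longer chain, or one carrying an amine, would give a step of similar size. On these data alone, it is also open whether a fluoro or methoxy group on that aromatic carbon would leave the step unchanged, as chloro and methyl do here.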